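Purine Core Variants Against Leukemia Cell Growth

This account rests on a few compounds, and the source may have more. Where it says the series, first, only, none or still open, it means among the compounds named here.

Compound 1 `COc1ccc(N(C)c2ncnc3c2ncn3Cc2ccc(OC)c(OC)c2)cc1`: > 100000 nM
Compound 2 `COc1ccc(N(C)c2ncnc3c2ncn3Cc2cc(OC)cc(OC)c2)cc1`: 42000 nM
Compound 3 `COc1ccc(Cn2cnc3c(Cl)ncnc32)cc1OC`: > 50000 nM

In a functional assay on K562 cells (Homo sapiens) for antiproliferative activity, read by MTT assay, with a stated time of 48 h (a lower number here means a stronger inhibitor of growth, a higher number a weaker inhibitor of growth), compound 1 stands at a limit of the assay, not a number, > 100000 nM. Among the measured compounds shown here, compound 2 is the only compound with a counted number, giving 42000 nM in this assay. Compound 3 also sits at a limit, > 50000 nM. The two cores differ as 3,5-dimethoxyphenyl in place of 3,4-dimethoxyphenyl on a saturated chain carbon bound to an aromatic nitrogen, and this gave an at least 2.3-fold lower number from compound 1 to compound 2 (0.37 log units; beyond the scatter). The change chloro in place of (4-methoxyphenyl)(methyl)amino on an aromatic carbon gave a step that the two limits leave unreadable from compound 1 to compound 3, a step unreadable because of the limit of > 100000 nM in this assay, at which 1 of the 3 values shown sits, and (the limit of > 50000 nM in this assay, at which 1 of the 3 values shown sits). Compound 4 `COc1cc(Cn2cnc3c(Cl)ncnc32)cc(OC)c1` carries the same change, (chloro in place of (4-methoxyphenyl)(methyl)amino on an aromatic carbon), on the core of compound 2. Since the measured step from compound 1 to compound 3 is unreadable, no size can be carried over; compound 4 is expected to weaken, a 1.7-fold higher number from compound 2 to compound 4 (0.22 log units; within the scatter). Compound 4 is estimated at 70000 nM in this assay.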

Compound 4, concentration for 50% growth inhibition: > 100000 nM
Compound 4: no number, only a limit; the forecaster's own chance of this, stated with the estimate: 55%; middle value at least 1.4-fold (0.15 log units) away from the limit.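

In this assay, chloro in place of (4-methoxyphenyl)(methyl)amino on an aromatic carbon gave an at least 2.3-fold higher number from compound 2 to compound 4 (0.37 log units; beyond the scatter). Among the compounds shown here, this is the only readable instance of the change, and its full size stays unknown, since compound 4 stands at a limit: the limit of > 100000 nM in this assay, at which 2 of the 4 values shown sit. The same change on the core of compound 1 cannot be read, so the series does not show whether the step carries from one core to another, as compound 3 also ends at a limit: the limit of > 50000 nM in this assay, at which 1 of the 4 values shown sits.

The compounds shown leave open whether a morpholine or a plain amino group on that aromatic carbon would match compound 2 at 42000 nM. Also open, as far as these compounds go, is what a longer chain between the aromatic nitrogen and the dimethoxyphenyl ring would give.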